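Fluoro in place of methoxy on compound 2

The source may report more compounds than this note shows. Statements on the series, on what has been measured and on what is new or still open speak of the compounds shown alone.

Of the compounds shown here, two have been measured in a functional assay, read by spectrophotometry, with a stated time of 30 min; a lower number here means a stronger inhibitor, a higher number a weaker inhibitor. Compound 1 `O=C(/C=C/c1ccccc1)NCCC1CCN(Cc2ccccc2)CC1` returns only a limit of the assay, > 200000 nM. Among the compounds with values here, compound 2 `COc1ccc(CN2CCC(CCNC(=O)/C=C/c3cc(C(C)(C)C)c(O)c(C(C)(C)C)c3)CC2)cc1` gives 61200 nM, the only actual number so far, so it has no measured neighbour to be ranked against. Compound 3 `CC(C)(C)c1cc(/C=C/C(=O)NCCC2CCN(Cc3ccc(F)cc3)CC2)cc(C(C)(C)C)c1O` departs from compound 2 in one place: fluoro in place of methoxy on an aromatic carbon. By group names, 4-methoxybenzyl becomes 4-fluorobenzyl. Within the data shown here, no measured pair shows what a single change at this place does, so the expectation rests on compound 2 and its 61200 nM alone. The expected result is a 1.1-fold lower number from compound 2 to compound 3 (0.05 log units; within the scatter), which means no change beyond the usual scatter of this assay and no favoured direction. For compound 3 the estimate is 55000 nM, with an expected range from 20000 nM to 170000 nM.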

Compound 3, half-maximal inhibitory concentration: 57500 nM
Compound 3: the middle estimate sits 1.0-fold (0.02 log units) below what was measured; low and high end bracket the measured number.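

In this assay, within the data shown here, going from 4-methoxybenzyl to 4-fluorobenzyl gives a 1.1-fold lower number from compound 2 to compound 3 (0.03 log units; within the scatter), the first step in this set that changes a single place. At this position on the aromatic ring, para to a large group, methoxy and fluoro therefore cannot be told apart, even though the change removes the oxygen and the hydrogen-bond acceptor counted on methoxy. Compound 3, like compound 2, returns an actual number and not a limit, a contrast with the one limit in this set: the limit of > 200000 nM in this assay, at which 1 of the 3 values shown sits.

The compounds shown leave open what an amine or a carboxylic acid at this position would do, as only methoxy and fluoro have been read there. They also leave open whether a longer chain in place of the benzyl link would move the number.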